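The source may hold more compounds than are shown below. What is called first, only, known or untested is meant among the compounds shown, and "the series" means these compounds.

The compounds measured so far in an assay on a protein complex for inhibition of CDK8/Cyclin C (Homo sapiens), with a stated time of 1 h, tested at 10 uM; on this read-out lower numbers stand for less inhibition and higher numbers for more inhibition at the one concentration tested (going by the name of the read-out):

compound 2 `CNC(=O)CCc1ccncc1-c1ccc2ccccc2c1` gives 100%;
compound 3 `Cn1ccc2cc(-c3cnccc3/C=C/C(=O)N3CCOCC3)ccc21` gives 97%;
compound 1 `Cn1ncc2cc(-c3cnccc3/C=C/C(=O)N3CCOCC3)ccc21` gives 95%.

Compound 2 holds the highest of the three numbers in this assay, but this says little on its own: the number of compound 3 lies within the usual scatter of it, and so does the number of compound 1. All three readings sit close to the top of the read-out, and none of the three pairs is separated by more than repeated measurements would scatter.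

Compound 4 `O=C(/C=C/c1ccncc1-c1ccc2ccccc2c1)NC1CC1` is the next compound, not yet measured. It differs from compound 2 in one place: 2-(cyclopropylcarbamoyl)ethenyl in place of 2-(methylcarbamoyl)ethyl on an aromatic carbon. Among the compounds with values here, no step between measured compounds maps onto this change, so nothing measured here tells how large its effect should be. Given that every measured compound in this assay reads near the top of the read-out, the reasonable expectation is a step of none beyond the scatter, with any movement more likely downward than upward, since the read-out has little room above the number of compound 2.

Compound 4 is therefore expected to give about 94% in this assay, with a range from 80% to 100%. That estimate means a step of a number 6 percentage points lower from compound 2 to compound 4 (within the scatter), expected to stay within the usual scatter.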

Compound 4, a percentage reported as inhibition, at one concentration (the size of the read-out at that concentration, not a potency): 102%
Beside the measured number, compound 4's estimate is 8 percentage points below it; measured number outside the range, above it.
By their numbers in this assay, from the lowest: compounds 1, 3, 2 and 4 (each within the scatter of the next).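

In this assay, within the data shown here, swapping 2-(methylcarbamoyl)ethyl for 2-(cyclopropylcarbamoyl)ethenyl on this aromatic carbon, ortho to a large group and opposite the ring nitrogen, gives a number 2 percentage points higher from compound 2 to compound 4 (within the scatter) and is the first step that can be read at this place. The reading stays near the top of the scale with a group of 8 heavy atoms in place of one of 6, carrying a three-membered carbon ring and an added double bond outside the aromatic rings, so at the one concentration tested this position accepts the bigger group without a visible loss of inhibition. No measurement offered here explains this result.

The step changes the chain and the amide substituent together, so the compounds shown cannot say what either change does alone, as the 2-(methylcarbamoyl)ethenyl and 2-(cyclopropylcarbamoyl)ethyl groups are absent from them, and with all readings close to the top of the scale, differences in potency could stay hidden. Going by these compounds, it also remains open whether inhibition would hold with a carboxylic acid or an amine at the end of the chain in place of the amide.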